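Hydroxy in Place of Amino: Expectation for Compound 4

A few compounds are considered here, and "the series" means these few. Any claim that something is new, unique, unknown or untested is made for them only; others in the source may bear on it.

In a functional assay on cells (Endothelial cell, Bos taurus) for antiproliferative activity (on this read-out lower numbers stand for stronger inhibition and higher numbers for weaker inhibition), the three measured compounds gave the following numbers:
compound 1 `COc1ccc(/C=C(/F)c2cc(OC)c(OC)c(OC)c2)cc1O`: 1700 nM
compound 2 `COc1ccc(/C=C(/F)c2cc(OC)c(OC)c(OC)c2)cc1N`: 2000 nM
compound 3 `COc1ccc(/C(F)=C(/F)c2cc(OC)c(OC)c(OC)c2)cc1N`: 3600 nM

Compound 4 `COc1ccc(/C(F)=C(/F)c2cc(OC)c(OC)c(OC)c2)cc1O` has not yet been measured in this assay. It differs from compound 3 by hydroxy in place of amino on an aromatic carbon. The same change is seen between two measured compounds, where compound 1 differs from compound 2 by hydroxy in place of amino on an aromatic carbon, and there it produced a 1.2-fold lower number from compound 2 to compound 1 (0.07 log units; within the scatter). The difference between the cores of compound 2 and compound 3 is not broken down here; compound 3 gives the highest of the three numbers, and its gap to compound 1 lies beyond the scatter while its gap to compound 2 lies within it.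

For compound 4 a step of a 1.2-fold lower number from compound 3 to compound 4 (0.08 log units; within the scatter) in this assay is expected, resting on the step of a 1.2-fold lower number from compound 2 to compound 1 (0.07 log units; within the scatter), which was small. Compound 4 is therefore estimated at 3000 nM in this assay, within a range from 1500 nM to 6000 nM.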

Compound 4, half-maximal inhibitory concentration: 4600 nM
Compound 4: middle estimate off by 1.5-fold (0.19 log units), on the low side; low and high end bracket the measured number.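

On the second core, hydroxy in place of amino in this assay gave a 1.3-fold higher number from compound 3 to compound 4 (0.11 log units; within the scatter). Set beside the earlier step, the change reads the same on both cores as far as this assay can tell: the same change on two cores in this assay, a 1.2-fold lower number (0.07 log units; within the scatter) from compound 2 to compound 1 and a 1.3-fold higher number (0.11 log units; within the scatter) from compound 3 to compound 4, 1.5-fold (0.18 log units) apart, within the scatter of two such steps. This shows that swapping amino for hydroxy stayed a small step on both cores, but it does not show that the two steps are identical, and steps this small fix no direction for the change.

The compounds shown leave open whether a larger step would appear with a different group in this place, such as a carboxylic acid or an acetamide. They also leave open whether the small step holds on cores beyond these two.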